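This account rests on a few compounds, and the source may have more. Where it says the series, first, only, none or still open, it means among the compounds named here.

Compound 3 `Cc1[nH]cnc1CN1CCN(c2cccc(C#N)c2)C1=O` belongs to a small set that shares the same cyclic urea bearing an aryl group. In a functional assay (Cavia porcellus) for antagonist activity at Serotonin 3 (5-HT3) receptor (Homo sapiens) (a higher number here means a weaker inhibitor, a lower number a stronger inhibitor), compound 3 gives 134 nM, which is the highest number of the three measured. Its nearest neighbour on the numbers is compound 1 `O=C1N(c2cccc([N+](=O)[O-])c2)CCN1C1CN2CCC1CC2`, which carries a different amine on the other urea nitrogen and gives 75.2 nM in this assay; the two values lie within the scatter of each other. Far away stands compound 2 `Cc1[nH]cnc1CN1CCN(c2cccc(Br)c2)C1=O`, which gives 10.4 nM in this assay, and the one-place step a 13-fold higher number from compound 2 to compound 3 (1.11 log units; beyond the scatter) is a large one.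

Compound 4 `Cc1[nH]cnc1CN1CCN(c2cccc([N+](=O)[O-])c2)C1=O` is the next step from compound 3: nitro in place of cyano on an aromatic carbon. Among the measured compounds shown here, only one measured step touches the same aromatic carbon, and it shows that the bromo to cyano exchange moved this assay a long way. For the measured compounds named here, no measured pair isolates the cyano to nitro exchange, but compound 1 carries a nitro on the same aryl group and sits at a lower number than compound 3, though within the scatter. Weighing both, a step of a 2.2-fold lower number from compound 3 to compound 4 (0.35 log units; beyond the scatter) is expected, a moderate move toward a lower number. Compound 4 is therefore estimated at 60 nM in this assay, with a range from 15 nM to 250 nM.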

Compound 4, antagonist equilibrium constant: 125 nM
For compound 4 the middle estimate is 2.1-fold (0.32 log units) below the measured one; the range from low to high includes it.
By their numbers in this assay, from the lowest: compound 2; then compounds 1, 4 and 3 (each within the scatter of the next).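

In this assay, the exchange at this aromatic carbon gives a 1.1-fold lower number from compound 3 to compound 4 (0.03 log units; within the scatter), so nitro and cyano cannot be told apart here, although nitro brings one more heavy atom and one more hydrogen-bond acceptor than cyano. Bromo now stands apart from two replacements rather than one: a 12-fold higher number from compound 2 to compound 4 (1.08 log units; beyond the scatter) is a large step, as is a 13-fold higher number from compound 2 to compound 3 (1.11 log units; beyond the scatter), and both run the same way. With the nitro group kept on the aryl group, compound 1 gives 75.2 nM and compound 4 gives 125 nM, two values within the scatter of each other, so these two amines on the other urea nitrogen are not separated at this aryl group. Nothing measured in this set bears on why bromo departs from the other two groups.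

Whether the low number of compound 2 belongs to bromo alone stays open, since chloro, iodo, methyl and methoxy do not appear on this aromatic carbon among the compounds shown. Also open, going by these compounds, is whether the other amine would keep its number with bromo in place of nitro.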